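Swapping the pyridine substituent in an oxadiazole amide series

The source may hold more compounds than are shown below. What is called first, only, known or untested is meant among the compounds shown, and "the series" means these compounds.

Of the compounds shown here, two have been measured in an assay on T-REx-293 cells for inhibition of potassium channel subfamily T member 1 (Homo sapiens), read by patch clamp; a higher number here means a weaker inhibitor, a lower number a stronger inhibitor. Compound 1 `Cc1ccnc(-c2noc([C@H](C)NC(=O)c3cc(C(F)(F)F)nn3C)n2)c1` gives 4470 nM in this assay, while compound 2 `COCc1cc(-c2noc([C@H](C)NC(=O)c3cc(C(F)(F)F)nn3C)n2)ccn1` gives 322 nM. Going by the values given here, the one measured step, a 14-fold lower number from compound 1 to compound 2 (1.14 log units; beyond the scatter), exchanges both the attachment point and the substituent of the pyridine ring. Among the compounds with values here, compound 2 therefore holds the lowest of the two numbers, with compound 1 the only neighbour at a far higher value.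

Compound 3 `C[C@H](NC(=O)c1cc(C(F)(F)F)nn1C)c1nc(-c2ccnc(C(F)F)c2)no1` keeps the core of compound 2 and differs only in that (difluoromethyl in place of methoxymethyl on an aromatic carbon). Within the data shown here, no measured step isolates this exchange; the step from compound 1 to compound 2 altered the ring attachment as well, so it offers little direct guidance. With the pyridine attachment retained, the expected outcome is no step beyond the scatter, with a 1.2-fold higher number from compound 2 to compound 3 (0.09 log units; within the scatter) as the estimated change. Compound 3 is expected at 400 nM, within 130 nM to 1300 nM.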

Compound 3, half-maximal inhibitory concentration in the potassium channel subfamily T member 1 assay: 61 nM
For compound 3 the middle estimate is 6.6-fold (0.82 log units) above the measured one, and the stated range ends above it.
By their numbers in the potassium channel subfamily T member 1 assay, from the lowest: compound 3; then compound 2; then compound 1.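

In the potassium channel subfamily T member 1 assay, the exchange of methoxymethyl for difluoromethyl next to the ring nitrogen gives a 5.3-fold lower number from compound 2 to compound 3 (0.72 log units; beyond the scatter), so with the pyridine attachment held fixed, this substituent alone moves the number beyond the scatter, which the earlier step, with its change of attachment, could not show. Taken across the whole pyridine group, which also changes its attachment, the difference reaches a 73-fold lower number from compound 1 to compound 3 (1.86 log units; beyond the scatter), leaving compound 3 as the strongest inhibitor of the three. The same exchange also raises the number in a physicochemical assay for lipophilicity; a lower number here means a more polar compound, a higher number a more lipophilic compound: the measured distribution coefficient of compound 2, 3, and of compound 3, 3.4, a number 0.40 log units higher (beyond the scatter)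

In the physicochemical assay compound 2 gives 3 and compound 3 gives 3.4. This single pair cannot separate the higher number in the physicochemical assay from any effect specific to difluoromethyl itself. From the compounds shown here alone, how a nitrile or an ethyl group at this position would compare in the potassium channel subfamily T member 1 assay remains open.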